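Methyl on the Benzyl Ring in a Chain-Shortened Analogue

A few compounds are considered here, and "the series" means these few. Any claim that something is new, unique, unknown or untested is made for them only; others in the source may bear on it.

Compound 1 `CN(CCCCn1c(=O)oc2ccccc21)Cc1ccccc1` is the strongest of the three measured compounds: in an assay on membranes from liver for displacement of a labelled ligand from Sigma non-opioid intracellular receptor 1 (Rattus norvegicus), read by scintillation counting (a lower number here means a stronger inhibitor, a higher number a weaker inhibitor), compound 1 gives 2.6 nM. Compound 2 `Cc1cccc(CN(C)CCCCn2c(=O)oc3ccccc32)c1` carries methyl in place of hydrogen on an aromatic carbon and gives 102 nM, a step of a 39-fold higher number from compound 1 to compound 2 (1.59 log units; beyond the scatter). Compound 3 `CN(CCCn1c(=O)oc2ccccc21)Cc1ccccc1` has a shorter chain; how its core differs from that of compound 1 is not broken down here, and in this assay compound 3 gives 223 nM. Compound 4 `Cc1cccc(CN(C)CCCn2c(=O)oc3ccccc32)c1` differs from compound 3 by methyl in place of hydrogen on an aromatic carbon, the same change as that from compound 1 to compound 2. Resting on the size of a 39-fold higher number from compound 1 to compound 2 (1.59 log units; beyond the scatter), compound 4 is expected to show a weakening step of a 16-fold higher number from compound 3 to compound 4 (1.20 log units; beyond the scatter), though it starts from a weaker point. Compound 4 is estimated at 3500 nM, between 900 nM and 14000 nM.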

Compound 4, inhibition constant: 1840 nM
Compound 4: middle estimate off by 1.9-fold (0.28 log units), on the high side; measured number inside the range.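

In this assay the methyl group gives a higher number on both cores, and on the core with the shorter chain it gives an 8.3-fold higher number from compound 3 to compound 4 (0.92 log units; beyond the scatter). The direction of the change carries over from one core to the other, but its size does not: the same change on two cores in this assay, a 39-fold higher number (1.59 log units; beyond the scatter) from compound 1 to compound 2 and an 8.3-fold higher number (0.92 log units; beyond the scatter) from compound 3 to compound 4, 4.8-fold (0.68 log units) apart, beyond the scatter of two such steps. With only these two pairs, the series shows that the step cannot be transferred at face value, but it does not show how the size depends on chain length, nor why the two steps differ.

The compounds shown leave open what the same methyl change would do on a core with a longer chain. They also leave open how a methoxy group or a chlorine atom on the same aromatic carbon would compare.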